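The source may hold more compounds than are shown below. What is called first, only, known or untested is meant among the compounds shown, and "the series" means these compounds.

Measured compounds:
- compound 1 `CSc1cc(C(=O)N2CC=CC2)cc(C#N)c1O`: 58%
- compound 2 `N#Cc1cc(C(=O)N2CC=CC2)cc(Br)c1O`: 69%

In an assay on isolated protein for inhibition of solute carrier family 22 member 12 (Homo sapiens), tested at 3 uM (on this read-out higher numbers stand for more inhibition at the one concentration tested (going by the name of the read-out) and lower numbers for less inhibition), compound 2 gives the highest of the two numbers; the nearest is compound 1, and the step of a number 11 percentage points higher from compound 1 to compound 2 (beyond the scatter) lies beyond the usual scatter. Compound 3 `CCCc1cc(C(=O)N2CC=CC2)cc(C#N)c1O` has not yet been measured. It differs from compound 2 in one place: propyl in place of bromo on an aromatic carbon. Bromo leaves and propyl enters, so the group on that aromatic carbon is a chain of three carbon atoms rather than a single bromine.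

For the measured compounds named here, only one measured step bears on this change, and only loosely: the step from compound 1 to compound 2 also swapped the group at this same aromatic carbon, trading methylsulfanyl for bromo, and the reading rose by a number 11 percentage points higher from compound 1 to compound 2 (beyond the scatter). Going by the values given here, that shows the position is sensitive to what sits there, but no measured compound carries an alkyl chain at this place, so the direction for propyl cannot be read directly. A modest fall back toward the value of compound 1, or no change beyond the scatter, seems the most reasonable expectation, giving an expected step of a number 9 percentage points lower from compound 2 to compound 3 (within the scatter) in this assay.

Compound 3 is therefore estimated at 60%, with a likely range from 42% to 76%.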

Compound 3, a percentage reported as inhibition, at one concentration (the size of the read-out at that concentration, not a potency): 70%
Beside the measured number, compound 3's estimate is 10 percentage points below it; the range from low to high includes it.
By their numbers in this assay, from the lowest: compound 1; then compounds 2 and 3 (each within the scatter of the next).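

In this assay, putting propyl where bromo stood gives a number 1 percentage points higher from compound 2 to compound 3 (within the scatter) and so leaves the reading unchanged within the usual scatter, which means this aromatic carbon, ortho to a hydroxy group, takes a chain of three carbon atoms as readily as a single bromine. Set against methylsulfanyl, the same propyl group gives a number 12 percentage points higher from compound 1 to compound 3 (beyond the scatter) and so matches what bromo did at this carbon, which leaves methylsulfanyl as the only one of the three groups whose reading stands apart from the others. No measured information is available to explain why bromo and propyl read alike here.

The compounds shown leave open how far this level reading extends, for example whether a longer chain such as butyl or a branched one such as isopropyl would hold the reading at the level of compound 2 and compound 3. They also leave open what an amine or a carboxylic acid on this same carbon would do, and whether the match between bromo and propyl would persist in a full potency measurement rather than a reading at one concentration.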